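Chloro for Hydrogen on the Benzyl Ring: Compound 4

The compounds below may be only part of what the source reports. "The series", "measured", "known", "first", "only" and "open" are said of these compounds alone.

Compound 3 `Nc1cccc(/C=C2\SC(=O)N(Cc3ccccc3)C2=O)c1` stands at a limit in a functional assay on FM3A cells (Mus musculus) for cytotoxicity, read by cell counting, with a stated time of 2 days; on this read-out lower numbers stand for stronger inhibition and higher numbers for weaker inhibition: compound 3 gives > 250000 nM. Compound 2 `Nc1cccc(/C=C2\SC(=O)N(Cc3cccc(F)c3)C2=O)c1` likewise gives only a limit, > 250000 nM. Among the compounds with values here, compound 1 `Cc1ccc(CN2C(=O)S/C(=C\c3cccc(N)c3)C2=O)cc1` gives 158000 nM, the sole number in the set. The steps of an at least 1.5-fold higher number from compound 1 to compound 2 (0.19 log units; that floor lies within the scatter) and an at least 1.5-fold higher number from compound 1 to compound 3 (0.19 log units; that floor lies within the scatter) are floors only, and a step that the two limits leave unreadable from compound 2 to compound 3. Given (the limit of > 250000 nM in this assay, at which 2 of the 3 values shown sit), the series is barely resolved. Compound 4 `Nc1cccc(/C=C2\SC(=O)N(Cc3ccc(Cl)cc3)C2=O)c1` differs from compound 3 by chloro in place of hydrogen on an aromatic carbon. Within the data shown here, no measured step puts a group at that place, so the change is expected to yield an at least 1.1-fold lower number from compound 3 to compound 4 (0.05 log units; that floor lies within the scatter), within the scatter. Compound 4 is therefore estimated at 220000 nM, between 100000 nM and 600000 nM, most likely once more reported as a limit.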

Compound 4, half-maximal inhibitory concentration: 246000 nM
The estimate for compound 4 lay 1.1-fold (0.05 log units) below the measured number; the range from low to high includes it.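

In this assay compound 4 gives 246000 nM as a true number, so 4-chlorophenyl joins the 4-methylphenyl of compound 1 as a group that gives a reading at this place. The step of a 1.6-fold higher number from compound 1 to compound 4 (0.19 log units; within the scatter) does not separate chloro from methyl. The floors an at least 1.0-fold lower number from compound 3 to compound 4 (0.00 log units; that floor lies within the scatter) and an at least 1.0-fold lower number from compound 2 to compound 4 (0.00 log units; that floor lies within the scatter) stay within the scatter, so no gain over phenyl or 3-fluorophenyl is shown, and resolution remains poor: the limit of > 250000 nM in this assay, at which 2 of the 4 values shown sit.

As far as these compounds go, whether a carboxylic acid or an amine in place of the chloro would move the number beyond the scatter stays open.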